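Removing one fluoro from compound 3

The source may hold more compounds than are shown below. What is called first, only, known or untested is meant among the compounds shown, and "the series" means these compounds.

Values in a functional assay on SW480 cells (Homo sapiens) for antiproliferative activity, with a stated time of 72 h (a lower number here means a stronger inhibitor, a higher number a weaker inhibitor), so far:
Compound 1 `O=C(COc1ccc(CN2CC=C(c3c[nH]c4cccc(F)c34)CC2)c(F)c1)NO` gives 5560 nM here
Compound 2 `O=C(COc1ccc(CN2CC=C(c3c[nH]c4ccc(F)cc34)CC2)cc1)NO` gives 1110 nM here
Compound 3 `Cc1ccc2[nH]cc(C3=CCN(Cc4ccc(OCC(=O)NO)cc4F)CC3)c2c1` gives 1950 nM here

Compound 2 and compound 3 lie within the scatter of each other. Compound 1 stands apart, with the measured step being a 2.9-fold lower number from compound 1 to compound 3 (0.46 log units; beyond the scatter) for 5-methyl-1H-indol-3-yl in place of 4-fluoro-1H-indol-3-yl on a double-bonded ring carbon. Compound 4 `Cc1ccc2[nH]cc(C3=CCN(Cc4ccc(OCC(=O)NO)cc4)CC3)c2c1` is compound 3 with hydrogen in place of fluoro on an aromatic carbon and it has not yet been measured. Going by the values given here, the one measured step concerns a different group, so no step covers this change directly. Compound 2 also has hydrogen at this place and gives 1110 nM but it differs from compound 4 in another substituent as well, which makes it only a loose guide. No step beyond the scatter is therefore expected in this assay and any drift is expected to be slightly downward. The expected step is a 1.4-fold lower number from compound 3 to compound 4 (0.14 log units; within the scatter) and no larger. Compound 4 is estimated at 1400 nM with an expected range from 650 nM to 3000 nM as its likely span.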

Compound 4, half-maximal inhibitory concentration: 3960 nM
Compound 4: the middle estimate sits 2.8-fold (0.45 log units) below what was measured; measured number above the stated range.
By their numbers in this assay, from the lowest: compounds 2 and 3 (each within the scatter of the next); then compounds 4 and 1 (each within the scatter of the next).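

In this assay, going by these compounds alone, hydrogen in place of fluoro on this aromatic carbon, ortho to a large group, gives a 2.0-fold higher number from compound 3 to compound 4 (0.31 log units; beyond the scatter) and thus provides the first direct reading at this position: the fluoro-bearing compound has the lower number, by a modest margin. With hydrogen at this place in both compounds, methyl in place of fluoro on an aromatic carbon elsewhere in the molecule gives a 3.6-fold higher number from compound 2 to compound 4 (0.55 log units; beyond the scatter), so that second substituent also separates the two compounds beyond the scatter. Nothing measured here accounts for either step.

The compounds shown leave open whether this step is specific to fluoro or would also be seen with chloro, methoxy or an amine on the same carbon. They also do not show whether the step would keep its size with a fluoro rather than a methyl in the other position.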